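Swapping the Benzyl Substituent on the Way to Compound 3

The source may report more compounds than this note shows. Statements on the series, on what has been measured and on what is new or still open speak of the compounds shown alone.

Compound 1 `CCOC(=O)c1sc(-c2ccccn2)nc1N1CCC(NCc2ccc(OC)cc2)CC1` and compound 2 `CCOC(=O)c1sc(-c2ccccn2)nc1N1CCC(NCc2cccc(C(F)(F)F)c2)CC1` share the same core and differ only in the aryl group carried on a saturated chain carbon bound to an amine nitrogen. In an ADME assay on RAW264.7 cells (Mus musculus) for cytotoxicity, read by MTT assay, with a stated time of 72 h, tested at 50 uM (on this read-out higher numbers stand for more inhibition at the one concentration tested (going by the name of the read-out) and lower numbers for less inhibition), compound 1 gives 4.62%. In this assay, among the measured compounds shown here, compound 2 gives 19.2%, which is the highest of the two numbers available, and the step of a number 14.6 percentage points higher from compound 1 to compound 2 (beyond the scatter) is the only measured step so far.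

Compound 3 `CCOC(=O)c1sc(-c2ccccn2)nc1N1CCC(NCc2ccc(Cl)c(Cl)c2)CC1` continues from compound 2 with a single change: 3,4-dichlorophenyl in place of 3-(trifluoromethyl)phenyl on a saturated chain carbon bound to an amine nitrogen. For the measured compounds named here, the earlier step exchanged one aryl group for another at this very place and shifted the read-out modestly, so a change of comparable or smaller size seems the most likely outcome here; the two groups exchanged now both carry halogens, and no measured pair shows how they compare. Compound 3 is therefore expected to sit near compound 2, with a step of about a number 2.8 percentage points higher from compound 2 to compound 3 (within the scatter), giving an estimated 22% and a likely range from 6% to 42%.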

Compound 3, a percentage reported as inhibition, at one concentration (the size of the read-out at that concentration, not a potency): 30.1%
Estimate against measurement, compound 3: 8.1 percentage points below, and the stated range covers the measured number.
By their numbers in this assay, from the lowest: compound 1; then compound 2; then compound 3.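

In this assay, the position on a saturated chain carbon bound to an amine nitrogen still responds when one halogen-bearing aryl group replaces another: 3,4-dichlorophenyl in place of 3-(trifluoromethyl)phenyl gives a number 10.9 percentage points higher from compound 2 to compound 3 (beyond the scatter), so these two groups are not interchangeable here, even though each carries halogen atoms on one six-membered aromatic ring. Set against the methoxy-bearing group, the same 3,4-dichlorophenyl group gives a number 25.5 percentage points higher from compound 1 to compound 3 (beyond the scatter), which makes compound 3 the highest of the three and shows that the choice of aryl group at this one place can move the read-out by more than either single step suggested. Nothing measured alongside these numbers explains the rise, so the trend remains an observation and carries no mechanism.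

The compounds shown leave open whether the number depends on the two chlorine atoms together, as a single chlorine on the same ring would help to show. They also leave open how a carboxylic acid on the aryl ring, or a cyclohexyl ring in place of the aryl group, would behave at this position.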